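The compounds below may be only part of what the source reports. "The series", "measured", "known", "first", "only" and "open" are said of these compounds alone.

Compound 1 `CCN(CC)S(=O)(=O)c1ccc(S(=O)(=O)N2CCC[C@@H](C(=O)NC3CN(C(=O)OC(C)(C)C)C3)C2)cc1`: 1800 nM
Compound 2 `CCOC(=O)N1CCC[C@H](S(=O)(=O)c2ccc(S(=O)(=O)N(CC)CC)cc2)C1`: > 30000 nM

Of the compounds shown here, two have been tested in a functional assay on BXPC-3 cells (Homo sapiens) for inhibition, read by MTT assay, with a stated time of 7 days; a lower number here means a stronger inhibitor, a higher number a weaker inhibitor. Among the compounds with values here, compound 1 gives 1800 nM in this assay, the only plain number among the results so far. Compound 2 gives only a limit, > 30000 nM, so no number is known for it; this is the limit of > 30000 nM in this assay, at which 1 of the 2 values shown sits. Within the data shown here, compound 1 thus stands alone as the one measured compound with an actual value, and it is a weak inhibitor.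

The next compound, compound 3 `CCN(CC)C(=O)[C@@H]1CCCN(S(=O)(=O)c2ccc(S(=O)(=O)N(CC)CC)cc2)C1`, keeps the core of compound 1 and changes one place: diethylamino in place of (1-(tert-butoxycarbonyl)azetidin-3-yl)amino on a carbonyl carbon. The carbonyl carbon itself stays; what hangs on it shrinks from a four-membered non-aromatic ring carrying a tert-butoxycarbonyl group to a plain diethylamino group.

Among the measured compounds shown here, no step between two measured compounds is available, so no measured change guides the expectation. Starting from the weak value of compound 1, a loss somewhat beyond the scatter is expected, though a value within scatter cannot be ruled out. The expected step is a 2.8-fold higher number from compound 1 to compound 3 (0.44 log units; beyond the scatter). Compound 3 is estimated at 5000 nM, within a range from 1200 nM to 30000 nM, with a real chance that this assay reports only a limit.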

Compound 3, half-maximal inhibitory concentration: 10500 nM
The estimate for compound 3 lay 2.1-fold (0.32 log units) below the measured number; the range from low to high includes it.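

Changing what hangs on the carbonyl carbon clearly moves the result in this assay: diethylamino in place of (1-(tert-butoxycarbonyl)azetidin-3-yl)amino gives a 5.8-fold higher number from compound 1 to compound 3 (0.77 log units; beyond the scatter), so compound 1 is the stronger inhibitor of this pair and the rest of the structure does not set the activity alone. Within the data shown here, this is the first measured step at this place, and it shows that inhibition is weakened but not lost, since compound 3 still gives a plain number rather than a limit. The step swaps several features at once, including the four-membered ring, the tert-butoxycarbonyl group and the amide hydrogen, and nothing measured here assigns the change to any one of them.

Still open is which part of the larger group accounts for the difference: a plain azetidin-3-ylamino group without the tert-butoxycarbonyl group, or an ethylamino group that keeps the amide hydrogen, would help to separate these features. It is also unknown how a longer chain on the amide nitrogen, or a carboxylic acid in place of the amide, would fare at this carbonyl carbon.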